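The source may report more compounds than this note shows. Statements on the series, on what has been measured and on what is new or still open speak of the compounds shown alone.

Of the compounds shown here, two have been tested in an ADME assay on HEK-293T cells (Homo sapiens) for cytotoxicity, read by MTT assay, with a stated time of 24 h; on this read-out higher numbers stand for lower toxicity in this test and lower numbers for higher toxicity in this test. Compound 1 `Cc1cccc(NC(=O)CSc2nc(-c3ccccc3)cc(-c3ccccc3)c2C#N)c1` gives > 250000 nM, which is a limit and not a number. Compound 2 `COC(=O)[C@@H](NC(=O)CSc1nc(-c2ccccc2)cc(-c2ccc(C)cc2)c1C#N)C(C)C` gives > 250000 nM, which is also a limit. Compound 2 therefore stands at the limit of > 250000 nM in this assay, at which 2 of the 2 values shown sit. Compound 3 `CC[C@H](C)[C@H](NC(=O)CSc1nc(-c2ccccc2)cc(-c2ccc(C)cc2)c1C#N)C(=O)OC` departs from compound 2 by a single change, methyl in place of hydrogen on a saturated chain carbon, three bonds along the chain from an amide-type nitrogen and a carbonyl carbon, so that isopropyl becomes sec-butyl. Among the compounds with values here, no measured pair shows this change, and the only guide is the limit reached by compound 2. No step beyond the scatter is expected in this assay, and another limit is the likeliest report. The expected change is a number no higher from compound 2 to compound 3 (the limit leaves the size open). The estimate for compound 3 is 250000 nM, with an expected range of 120000 nM to 500000 nM.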

Compound 3, half-maximal cytotoxic concentration: 229000 nM
For compound 3 the middle estimate is 1.1-fold (0.04 log units) above the measured one, within the range that was stated.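

In this assay, within the data shown here, compound 3 gives 229000 nM, the first value in this set that is a number and not a limit. Methyl in place of hydrogen on this saturated chain carbon, turning isopropyl into sec-butyl, gives an at least 1.0-fold lower number from compound 2 to compound 3 (0.03 log units; that floor lies within the scatter). The sec-butyl compound thus gives this position a measured reference, but the true size of the step stays unknown, as compound 2 remains a limit: the limit of > 250000 nM in this assay, at which 2 of the 3 values shown sit.

From the compounds shown here alone, how far the value of compound 2 lies from that of compound 3 stays open, so a real effect of the methyl can be neither confirmed nor ruled out. Also open, going by these compounds, is whether a longer chain or an amine at this position, or a carboxylic acid in place of the methyl ester, would shift the number clearly beyond the scatter.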